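The compounds below may be only part of what the source reports. "The series", "measured", "known", "first", "only" and "open" are said of these compounds alone.

Among the compounds with values here, compound 2 `CCCCCCCCCCCS(=O)(=O)/C=C/c1ccc(O)c(O)c1` gives 11400 nM in a functional assay, read by fluorescence and spectrophotometry, with a stated time of 1 h (on this read-out lower numbers stand for an effect already at smaller amounts and higher numbers for an effect only at larger amounts of compound), the highest of the two numbers so far; compound 1 `C=CCCCCCCCS(=O)(=O)/C=C/c1ccc(O)c(O)c1` gives 6900 nM, the only neighbour, with a 1.7-fold higher number from compound 1 to compound 2 (0.22 log units; within the scatter). Compound 3 `O=S(=O)(/C=C/c1ccc(O)c(O)c1)CCCc1ccccc1` differs from compound 2 by phenyl in place of octyl on a saturated chain carbon, three bonds along the chain from a sulfonyl sulfur. Within the data shown here, the one measured step alters the far end of the chain, seven bonds along from the sulfonyl sulfur, and was within the scatter, so it bears only loosely on an exchange three bonds along; nothing measured separates an aromatic group from a chain at that place. The expected change is therefore a 1.3-fold lower number from compound 2 to compound 3 (0.10 log units; within the scatter), not beyond the scatter. For compound 3 the estimate in this assay is 9000 nM, range 3000 nM to 30000 nM.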

Compound 3, half-maximal effective concentration: 11500 nM
Compound 3: middle estimate off by 1.3-fold (0.11 log units), on the low side; measured number inside the range.
By their numbers in this assay, from the lowest: compounds 1, 2 and 3 (each within the scatter of the next).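

In this assay, phenyl in place of octyl on a saturated chain carbon, three bonds along the chain from a sulfonyl sulfur, gives a 1.0-fold higher number from compound 2 to compound 3 (0.00 log units; within the scatter) and phenyl in place of hex-5-en-1-yl gives a 1.7-fold higher number from compound 1 to compound 3 (0.22 log units; within the scatter) at the same place. Unlike the earlier step, these exchanges bring in a six-membered aromatic ring of carbon only, and the numbers remain within the scatter of both chain compounds. Nothing available explains this result.

Still open, as far as these compounds go, is whether an amine or a carboxylic acid at this place would also stay within the scatter. A longer chain ending in phenyl is equally unresolved.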